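A Cyano Group Added to the Pyridine of Compound 2

A few compounds are considered here, and "the series" means these few. Any claim that something is new, unique, unknown or untested is made for them only; others in the source may bear on it.

Measured compounds:
compound 1 `CCOc1cc(-c2ccc(C)cc2)cnc1Nc1cccc(C)n1` — 513 nM
compound 2 `CCOc1cc(-c2cccnc2)cnc1Nc1cccc(C)n1` — 12 nM

Both were tested in an assay on Ltk cells with metabotropic glutamate receptor 5 (Homo sapiens) as the target, read by fluorescence and calcium flux; a lower number here means a stronger inhibitor, a higher number a weaker inhibitor. Compound 2 stands at the lowest of the two numbers; its nearest neighbour is compound 1, and the step of a 43-fold lower number from compound 1 to compound 2 (1.63 log units; beyond the scatter) separates them. Compound 3 `CCOc1cc(-c2cccnc2C#N)cnc1Nc1cccc(C)n1` is not yet measured. It differs from compound 2 by cyano in place of hydrogen on an aromatic carbon. Among the measured compounds shown here, no measured step bears directly on this change: the only step on record, from compound 1 to compound 2, swaps one aromatic ring for another and says nothing about attaching a small group to the ring that compound 3 carries. With no guide, a shift beyond the scatter in either direction is possible but not expected; the estimated step is a 1.7-fold higher number from compound 2 to compound 3 (0.22 log units; within the scatter). Compound 3 is therefore expected to give about 20 nM, with a range from 5 nM to 80 nM.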

Compound 3, half-maximal inhibitory concentration: 80 nM
The estimate for compound 3 lay 4.0-fold (0.60 log units) below the measured number; low and high end bracket the measured number.
By their numbers in this assay, from the lowest: compound 2; then compound 3; then compound 1.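

In this assay, cyano on an aromatic carbon next to the ring nitrogen gives a 6.7-fold higher number from compound 2 to compound 3 (0.82 log units; beyond the scatter) and so costs inhibitory strength, which shows that this position of the pyridin-3-yl group is sensitive to substitution. The 2-cyanopyridin-3-yl group still outperforms 4-methylphenyl, with a 6.4-fold lower number from compound 1 to compound 3 (0.81 log units; beyond the scatter) as the change, so cyano gives back only part of the gain seen with a 43-fold lower number from compound 1 to compound 2 (1.63 log units; beyond the scatter) as the pyridin-3-yl group replaced 4-methylphenyl. No supporting data are available to explain this loss.

The compounds shown leave open whether the loss belongs to cyano itself or would also appear with another group here, such as a methyl, a fluorine atom or an amine. They also leave open how cyano would behave on the other carbons of this ring.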